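The source may hold more compounds than are shown below. What is called first, only, known or untested is meant among the compounds shown, and "the series" means these compounds.

Measured so far in a functional assay on NCI-H1299 cells (Homo sapiens), read by flow cytometry; on this read-out lower numbers stand for an effect already at smaller amounts and higher numbers for an effect only at larger amounts of compound:
compound 1 `N#Cc1ncc2nc1OCCCCCOc1ccc(CCO)cc1NC(=O)N2`: > 10000 nM
compound 2 `N#Cc1ncc2nc1OCCCCCOc1ccc(CCCO)cc1NC(=O)N2`: > 10000 nM

Both entries are limits of the assay, not numbers. Compound 2 has only a limit, > 10000 nM. Both compounds sit at the limit of > 10000 nM in this assay, at which 2 of the 2 values shown sit, so no number is available for either.

Compound 3 `N#Cc1ncc2nc1OCCCCCOc1ccc(OCCO)cc1NC(=O)N2` carries 2-hydroxyethoxy in place of 3-hydroxypropyl on an aromatic carbon. For the measured compounds named here, the only measured step is a step that the two limits leave unreadable from compound 1 to compound 2, so it gives no size to carry over to this change. No readable step in either direction is therefore expected in this assay, and the assay will most likely report a limit again. The estimated step is a step that the limit leaves unreadable from compound 2 to compound 3. For compound 3 the estimated value is 15000 nM, with an expected range from 5000 nM to 40000 nM.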

Compound 3, half-maximal effective concentration: > 10000 nM
Compound 3: a limit, no number; the forecaster's own chance of this, stated with the estimate: 75%; the middle value lies beyond the limit too.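

Compound 3 gives > 10000 nM in this assay as a limit and not a number. For the compounds shown here, no step among compound 1, compound 2 and compound 3 can be read, because all three rest on the same limit: the limit of > 10000 nM in this assay, at which 3 of the 3 values shown sit. The compounds shown leave open whether any change at this aromatic carbon gives a measurable value in this assay at all.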